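Trimming the acyl group: from bromopropenyl to vinyl

This account rests on a few compounds, and the source may have more. Where it says the series, first, only, none or still open, it means among the compounds named here.

The compounds share one core, an amide whose nitrogen carries a trimethoxyphenyl ring and a substituted benzyl group, and differ only in the group on the carbonyl carbon. Compound 1 `COc1ccc(CN(C(=O)C=C(C)C)c2cc(OC)c(OC)c(OC)c2)cc1O` gives 280 nM in a functional assay on KYSE-450 cells (Homo sapiens) for inhibition, read by MTT assay, with a stated time of 48 h; on this read-out higher numbers stand for weaker inhibition and lower numbers for stronger inhibition. Among the compounds with values here, compound 2 `COc1ccc(CN(C(=O)/C=C/CBr)c2cc(OC)c(OC)c(OC)c2)cc1O` gives 100 nM in this assay, the lowest of the two numbers measured, with compound 1 as its only neighbour. Within the data shown here, the single measured step, a 2.8-fold lower number from compound 1 to compound 2 (0.45 log units; beyond the scatter), swapped one group for another at the same carbonyl carbon and made inhibition modestly stronger.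

Compound 3 `C=CC(=O)N(Cc1ccc(OC)c(O)c1)c1cc(OC)c(OC)c(OC)c1` has not yet been measured. It differs from compound 2 by vinyl in place of 3-bromoprop-1-en-1-yl on a carbonyl carbon. Among the measured compounds shown here, no measured step replaces this particular group by vinyl, so the only guide is that changing the group on this carbonyl carbon shifted the number only modestly in the one step seen. A change of similar size, in either direction or none beyond the scatter, is therefore expected, with the step of a 1.5-fold higher number from compound 2 to compound 3 (0.18 log units; within the scatter) as the best guess. Compound 3 is estimated at 150 nM, within a range from 50 nM to 450 nM.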

Compound 3, half-maximal inhibitory concentration: 160 nM
Estimate against measurement, compound 3: 1.1-fold (0.03 log units) below; measured number inside the range.
By their numbers in this assay, from the lowest: compounds 2, 3 and 1 (each within the scatter of the next, the first and the last beyond it).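

In this assay, replacing 3-bromoprop-1-en-1-yl on the carbonyl carbon with vinyl, which has 2 heavy atoms against 4 and no bromine, gives a 1.6-fold higher number from compound 2 to compound 3 (0.20 log units; within the scatter), so this position tolerates losing both the bromine and part of the chain without a change that can be told from repeat-measurement noise. Replacing 2-methylprop-1-en-1-yl with vinyl gives a 1.8-fold lower number from compound 1 to compound 3 (0.24 log units; within the scatter), so compound 3 cannot be separated from either neighbour, although compound 1 and compound 2 do differ beyond the scatter. The earlier step therefore cannot be credited to the bromine alone, and the three compounds read as a shallow range rather than as a clear ranking of the groups. No measurement here explains why the number changes so little at this position. From the compounds shown here alone, all three groups keep a double bond, so it remains open whether a saturated ethyl group, a longer chain, a phenyl ring or an amine on this carbonyl carbon would give a similar number.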